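A few compounds are considered here, and "the series" means these few. Any claim that something is new, unique, unknown or untested is made for them only; others in the source may bear on it.

In an assay for binding affinity to dual specificity mitogen-activated protein kinase kinase 4 (Homo sapiens), read by KINOMEscan, tested at 100 nM (a lower number here means a stronger effect, a higher number a weaker effect of the compound at the concentration tested), compound 1 `CCCS(=O)(=O)Nc1ccc(F)c(C(=O)c2n[nH]c3ncc(-c4ccc(F)cc4)cc23)c1F` gives 2.1%, compound 2 `CCCS(=O)(=O)Nc1ccc(F)c(C(=O)c2n[nH]c3ncc(-c4cc(Cl)cc(Cl)c4)cc23)c1F` gives 73% and compound 3 `CCCS(=O)(=O)Nc1ccc(F)c(C(=O)c2n[nH]c3ncc(-c4ccc([N+](=O)[O-])cc4)cc23)c1F` gives 4.2%. Compound 3 thus holds the second highest of the three numbers; its nearest neighbour is compound 1, with a number 2.1 percentage points higher from compound 1 to compound 3 (within the scatter), and its furthest is compound 2, with a number 68.8 percentage points lower from compound 2 to compound 3 (beyond the scatter).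

Compound 4 `CCCS(=O)(=O)Nc1ccc(F)c(C(=O)c2n[nH]c3ncc(-c4ccc(S(N)(=O)=O)cc4C)cc23)c1F` is not yet measured. It differs from compound 3 in one place: 2-methyl-4-sulfamoylphenyl in place of 4-nitrophenyl on an aromatic carbon. The measured steps that bear on an exchange of this aryl group are a number 70.9 percentage points higher from compound 1 to compound 2 (beyond the scatter) and a number 68.8 percentage points lower from compound 2 to compound 3 (beyond the scatter), both large, whereas a number 2.1 percentage points higher from compound 1 to compound 3 (within the scatter) stayed within the scatter. The two compounds carrying 4-fluorophenyl or 4-nitrophenyl, compound 1 and compound 3, sit low; the one carrying 3,5-dichlorophenyl, compound 2, sits high. The entering 2-methyl-4-sulfamoylphenyl group resembles 4-fluorophenyl and 4-nitrophenyl more than 3,5-dichlorophenyl in its naming, but it adds a methyl and a sulfamoyl for which none of the three measured compounds gives guidance, so the outcome is uncertain and a wide range is needed.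

Compound 4 is expected to give 15%, between 2% and 60%. The expected step is therefore a number 10.8 percentage points higher from compound 3 to compound 4 (beyond the scatter), a rise that is estimated to stay close to the scatter, with real risk of a larger one.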

Compound 4, a percentage reported as activity, at one concentration (the size of the read-out at that concentration, not a potency): 3.1%
Estimate against measurement, compound 4: 11.9 percentage points above, and the stated range covers the measured number.
By their numbers in this assay, from the lowest: compounds 1, 4 and 3 (each within the scatter of the next); then compound 2.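

In this assay, the larger 2-methyl-4-sulfamoylphenyl group in place of 4-nitrophenyl gives a number 1.1 percentage points lower from compound 3 to compound 4 (within the scatter), and in place of 4-fluorophenyl it gives a number 1 percentage points higher from compound 1 to compound 4 (within the scatter), so this aromatic carbon, two atoms from the ring nitrogen, carries a ring with both a methyl and a sulfamoyl group with no change beyond the scatter. Against 3,5-dichlorophenyl the step is a number 69.9 percentage points lower from compound 2 to compound 4 (beyond the scatter), which leaves compound 2 as the only one of the four compounds with a high number and makes 3,5-dichlorophenyl the sole exchange at this position with a large effect so far. No measurement at hand accounts for this split among the aryl groups.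

As far as these compounds go, it remains open whether a single chlorine, as in 3-chlorophenyl or 4-chlorophenyl, already gives a number like that of compound 2, and whether 2-methylphenyl or 4-sulfamoylphenyl alone reads like the combined group of compound 4. Also open, from the compounds shown here alone, are a non-aromatic group such as morpholine at this carbon and whether compound 1, compound 3 and compound 4 would separate at a lower concentration.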